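Replacing 3-chlorophenyl with 2-chloropyridin-3-yl in compound 3

The source may hold more compounds than are shown below. What is called first, only, known or untested is meant among the compounds shown, and "the series" means these compounds.

Measured in an ADME assay on Vero cells (Chlorocebus sabaeus) for cytotoxicity, read by MTT assay, with a stated time of 72 h; a higher number here means that more compound is needed for the effect, a lower number that less compound is needed:
- compound 1 `O=C(Nc1nc(-c2ccccn2)cs1)c1ccccc1O`: "not determined" (no result reported)
- compound 2 `O=C(Nc1nc(-c2ccccn2)cs1)c1ccccc1Cl`: 2000 nM
- compound 3 `O=C(Nc1nc(-c2ccccn2)cs1)c1cccc(Cl)c1`: 7000 nM

Of the two numbers available in this assay, compound 3 has the higher, at 7000 nM, and compound 1 offers no number for comparison. The next compound, compound 4 `O=C(Nc1nc(-c2ccccn2)cs1)c1cccnc1Cl`, carries 2-chloropyridin-3-yl in place of 3-chlorophenyl on a carbonyl carbon. Among the measured compounds shown here, only one measured step bears on this change: a 3.5-fold higher number from compound 2 to compound 3 (0.54 log units; beyond the scatter), which is modest and beyond the scatter. It moves the chlorine-bearing group but does not test a ring with a hetero atom, so the data say nothing direct about that part of the change. The name of the entering group reads closer to the 2-chlorophenyl of compound 2, at 2000 nM, so a small move toward a lower number is expected. The expected change is a 1.4-fold lower number from compound 3 to compound 4 (0.15 log units; within the scatter), which may not clear the scatter. For compound 4 the estimated value is 5000 nM, with an expected range from 1500 nM to 18000 nM.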

Compound 4, half-maximal effective concentration: 1900 nM
Estimate against measurement, compound 4: 2.6-fold (0.42 log units) above, within the range that was stated.
By their numbers in this assay, from the lowest: compounds 4 and 2 (each within the scatter of the next); then compound 3.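

In this assay, among the compounds shown here, the change to 2-chloropyridin-3-yl on the carbonyl carbon gives a 3.7-fold lower number from compound 3 to compound 4 (0.57 log units; beyond the scatter), the first step here to test a ring with a hetero atom rather than one of carbon only. Set against 2-chlorophenyl, the same entering group gives a 1.1-fold lower number from compound 2 to compound 4 (0.02 log units; within the scatter), so placing a hetero atom in that chlorine-bearing ring produces no readable difference in this assay. Nothing measured here accounts for either step.

Compound 1 has no result, so these steps cannot be compared with a ring that carries a hydroxyl group. From the compounds shown here alone, it remains open whether 2-chlorophenyl and 2-chloropyridin-3-yl would still read alike if a methoxy group or an amine took the place of the chlorine.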